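This account rests on a few compounds, and the source may have more. Where it says the series, first, only, none or still open, it means among the compounds named here.

Measured compounds:
compound 1 `CCCCC(OC(=O)CN1CCN(CCCCOc2ccc(-c3cc(=S)ss3)cc2)CC1)c1ccccc1C(=O)Oc1ccc(/C=C/C(=O)OCCCCO[N+](=O)[O-])cc1OC`, 360000 nM
compound 2 `CCCCC(OC(=O)CN1CCN(CCCCCCOc2ccc(-c3cc(=S)ss3)cc2)CC1)c1ccccc1C(=O)Oc1ccc(/C=C/C(=O)OCCCCO[N+](=O)[O-])cc1OC`, 390000 nM
compound 3 `CCCCC(OC(=O)CN1CCN(CCCCOc2ccc(-c3cc(=S)ss3)cc2)CC1)c1ccccc1C(=O)Oc1ccc(/C=C/C(=O)OCCCCCCO[N+](=O)[O-])cc1OC`, 320000 nM

In a functional assay on a cell-free system (Platelet, plasma, Oryctolagus cuniculus) for inhibition, read by turbidimetry, with a stated time of 5 min (on this read-out lower numbers stand for stronger inhibition and higher numbers for weaker inhibition), compound 1 gives 360000 nM and compound 3 gives 320000 nM. The difference between them is 2-(nitrooxy)ethyl in place of nitrooxy on a saturated chain carbon, four bonds along the chain from an oxygen next to a carbonyl group and the step is a 1.1-fold lower number from compound 1 to compound 3 (0.05 log units; within the scatter). Compound 2 gives 390000 nM in this assay; the difference between the cores of compound 1 and compound 2 is not broken down here, and their values lie close together.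

Compound 4 `CCCCC(OC(=O)CN1CCN(CCCCCCOc2ccc(-c3cc(=S)ss3)cc2)CC1)c1ccccc1C(=O)Oc1ccc(/C=C/C(=O)OCCCCCCO[N+](=O)[O-])cc1OC` is not yet measured. It differs from compound 2 by 2-(nitrooxy)ethyl in place of nitrooxy on a saturated chain carbon, four bonds along the chain from an oxygen next to a carbonyl group, the same change as from compound 1 to compound 3. Because that step was a 1.1-fold lower number from compound 1 to compound 3 (0.05 log units; within the scatter), a step of about a 1.1-fold lower number from compound 2 to compound 4 (0.05 log units; within the scatter) is expected here too. The estimate for compound 4 in this assay is 350000 nM, with an expected range from 200000 nM to 600000 nM.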

Compound 4, half-maximal inhibitory concentration: 190000 nM
Compound 4: middle estimate off by 1.8-fold (0.27 log units), on the high side; measured number outside the range, below it.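

In this assay, putting 2-(nitrooxy)ethyl in place of nitrooxy gives a 2.1-fold lower number from compound 2 to compound 4 (0.31 log units; beyond the scatter), while the same change on the core of compound 1 stayed within the scatter. The two steps cannot be told apart: the same change on two cores in this assay, a 1.1-fold lower number (0.05 log units; within the scatter) from compound 1 to compound 3 and a 2.1-fold lower number (0.31 log units; beyond the scatter) from compound 2 to compound 4, 1.8-fold (0.26 log units) apart, within the scatter of two such steps. The data therefore give no sign that the two cores respond differently, but they do not prove that the step transfers, and two pairs cannot establish a rule for the series.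

Still open, on these data alone, is how the read-out responds to a chain longer than those in compound 3 and compound 4. Also open, as far as these compounds go, is the effect of replacing the terminal nitrooxy with a carboxylic acid or an amine.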